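Amide reversal on the piperidine carbon: compound 4 note

The source may hold more compounds than are shown below. What is called first, only, known or untested is meant among the compounds shown, and "the series" means these compounds.

The series shares one core, varied at the saturated ring attached to the core. Compound 1 `Cc1nc(N2CCN(C3CCOCC3)CC2)nc2ccc(NC(=O)COc3ccc(Cl)cc3)cc12`, compound 2 `Cc1nc(N2CCC(NC(=O)C(C)C)CC2)nc2ccc(NC(=O)COc3ccc(Cl)cc3)cc12` and compound 3 `Cc1nc(N2CCC(N3CCCC3)CC2)nc2ccc(NC(=O)C(C)Oc3ccc(Cl)cc3)cc12` have been measured in an ADME assay on microsomes from liver (Mus musculus) for metabolic stability, read by HPLC, with a stated time of 30 min, tested at 10 uM; a higher number here means that more of the compound is left, a lower number that less of the compound is left. Compound 1 gives 1%. Compound 2 gives 9%, the second highest of the three numbers; compound 1 lies within the scatter of it, while compound 3, with 34%, sits a number beyond the scatter above it. Among the measured compounds shown here, compound 3 also differs in more than one place, so no single step between measured compounds is available.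

Compound 4 `Cc1nc(N2CCC(C(=O)NC(C)C)CC2)nc2ccc(NC(=O)COc3ccc(Cl)cc3)cc12` has not yet been measured in this assay. It differs from compound 2 in one place: isopropylcarbamoyl in place of (isopropylcarbonyl)amino on a saturated ring carbon, the two having the same atoms joined differently. For the measured compounds named here, with no measured pair that isolates this kind of rearrangement, the expectation rests on the position of compound 2 alone: the step from compound 2 to compound 4 is expected to be small and within the usual scatter, at a number 5 percentage points higher from compound 2 to compound 4 (within the scatter). Compound 4 is accordingly estimated to give 14% in this assay, with a range from 3% to 38%.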

Compound 4, percent of the compound remaining in the liver assay: 11%
Compound 4: the middle estimate sits 3 percentage points above what was measured; the measured number falls inside the stated range.
By their numbers in the liver assay, from the lowest: compounds 1, 2 and 4 (each within the scatter of the next); then compound 3.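

Among the compounds shown here, in the liver assay, compound 2 gives 9% and compound 4 gives 11%, the first change that can be read in one place, and a number 2 percentage points higher from compound 2 to compound 4 (within the scatter): with isopropylcarbamoyl in place of (isopropylcarbonyl)amino on the saturated ring carbon, three ring bonds from the ring nitrogen, the same atoms joined differently give no separable result. In a physicochemical assay for solubility, in phosphate buffer (a higher number here means a more soluble compound, a lower number a less soluble compound), compound 2 gives 205000 nM and compound 4 gives 132000 nM, and the same change gives a 1.6-fold lower number from compound 2 to compound 4 (0.19 log units; within the scatter), so neither read-out distinguishes the two arrangements at this position, and the direction of the amide on this ring carbon is not shown to matter for either measurement. No measurement available here explains why the two arrangements read alike.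

On these data alone, both compounds carry an isopropyl group on the amide, so it remains open whether the same indifference to amide direction would hold with a methyl group, a cyclopropyl group or a longer chain in its place. As far as these compounds go, it also remains open whether a different group on this ring carbon, such as a primary amine or a carboxylic acid, would give a step beyond the scatter in either read-out.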